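A Propyl Chain in Place of Ethyl

The compounds below may be only part of what the source reports. "The series", "measured", "known", "first", "only" and "open" are said of these compounds alone.

Three related amides have been measured so far in a functional assay on the whole organism with Mus musculus as the target (on this read-out higher numbers stand for an effect only at larger amounts of compound and lower numbers for an effect already at smaller amounts), on live mice. Compound 1 (`NC(=O)/C=C1/CCc2ccc(F)cc21`) gives 64 mg/kg in this test, compound 2 (`CCNC(=O)/C=C1\CCc2ccc(F)cc21`) gives 70 mg/kg in this test, and compound 3 (`O=C(/C=C1\CCc2c(F)cccc21)NC1CC1`) gives 126 mg/kg in the same test. Compound 2 lies within the scatter of both other compounds, so these numbers do not separate the three. No two of them differ in one place only, so no single structural change has yet been measured directly.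

Compound 4 (`CCCNC(=O)/C=C1\CCc2ccc(F)cc21`) extends the side chain of compound 2. The difference is methyl in place of hydrogen on a saturated chain carbon, two bonds along the chain from an amide-type nitrogen in the structure: methyl in place of hydrogen on a saturated chain carbon, two bonds along the chain from an amide-type nitrogen. This turns ethyl to propyl.

Compound 1 at 64 mg/kg and compound 2 at 70 mg/kg sit within the scatter of each other despite their different amide sides, so no step beyond the scatter is expected in this assay here. The expected step of a 1.1-fold higher number from compound 2 to compound 4 (0.06 log units; within the scatter) is small and stays within the scatter. For compound 4 the estimated value is 80 mg/kg with 38 mg/kg to 165 mg/kg as its expected range.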

Compound 4, dose for half-maximal effect: > 100 mg/kg
Compound 4 was reported as a limit; the forecaster's own chance of this, stated with the estimate: 3%; at least 1.2-fold (0.09 log units) between middle value and limit.
By their numbers in this assay, from the lowest: compounds 1, 2 and 3 (each within the scatter of the next).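

In this assay compound 4 gives > 100 mg/kg, which is a limit of the assay and not a number. Among these compounds, the change from ethyl to propyl, methyl in place of hydrogen on a saturated chain carbon, two bonds along the chain from an amide-type nitrogen, gives an at least 1.4-fold higher number from compound 2 to compound 4 (0.15 log units; that floor lies within the scatter), and this is the first step that can be read at a single place. It fixes only a floor for the change at this position, so the result shows a direction that cannot be told apart from the scatter, and the true size of the step remains unknown: the limit of > 100 mg/kg in this assay, at which 1 of the 4 values shown sits.

The compounds shown leave open whether the effect of lengthening this chain would reach beyond the scatter if the read-out gave a number for compound 4, and whether a shorter or longer side chain would follow the same direction. A methyl group or a butyl chain on the amide nitrogen, or an amine or a carboxylic acid at the end of the propyl chain, would each put a different group at this same end of the molecule on the shared core.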